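This account rests on a few compounds, and the source may have more. Where it says the series, first, only, none or still open, it means among the compounds named here.

Measured so far:
compound 1 `N#Cc1cc(Cl)c(Nc2nc3c(Nc4ccc(C(F)(F)F)cc4)ncnc3s2)c(Cl)c1` with 95 nM in a functional assay on HEK293 cells for antagonist activity at transient receptor potential cation channel subfamily V member 1 (Homo sapiens), read by calcium flux; a lower number here means a stronger inhibitor, a higher number a weaker inhibitor
compound 2 `FC(F)(F)c1cccc(Nc2ncnc3sc(Nc4c(Cl)cccc4Cl)nc23)c1` with 206 nM in this assay
compound 3 `Clc1cccc(Cl)c1Nc1nc2c(Nc3ccccc3)ncnc2s1` with 176 nM in this assay

Among these three numbers compound 3 has the second highest. Its nearest neighbour is compound 2, and the gap to compound 1, the furthest, is also within the scatter, so nothing separates the three in this assay.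

Compound 4 `CSc1ccc(Nc2ncnc3sc(Nc4c(Cl)cccc4Cl)nc23)cc1` is not yet measured. It differs from compound 3 by methylsulfanyl in place of hydrogen on an aromatic carbon. Within the data shown here, the only step with a direct bearing is the change of the substituent on the same outer ring: a 1.2-fold lower number from compound 2 to compound 3 (0.07 log units; within the scatter). Removing a trifluoromethyl there changed nothing that the assay could resolve. Compound 1, with a different substituent on that ring and a nitrile elsewhere, gives a number that also lies within the scatter of compound 3. The shared core therefore appears to set the potency, and the outer ring tolerates at least these decorations. The expected change is a 1.2-fold lower number from compound 3 to compound 4 (0.07 log units; within the scatter), a step within the scatter, in no particular direction. Compound 4 is expected at 150 nM, within a range of 60 nM to 400 nM.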

Compound 4, half-maximal inhibitory concentration: 96 nM
Estimate against measurement, compound 4: 1.6-fold (0.19 log units) above; the measured number falls inside the stated range.
By their numbers in this assay, from the lowest: compounds 1, 4, 3 and 2 (each within the scatter of the next, the first and the last beyond it).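

Placing methylsulfanyl on the outer ring, para to a large group, gives a 1.8-fold lower number from compound 3 to compound 4 (0.26 log units; within the scatter) in this assay, so this carbon accepts the added group with no change that the assay can resolve. Among these compounds, the one earlier single change on this ring, a 1.2-fold lower number from compound 2 to compound 3 (0.07 log units; within the scatter), involved trifluoromethyl, whereas this step shows the same outcome with a sulfur-bearing group. Nothing measured here offers an explanation for this result.

From the compounds shown here alone, whether methoxy, an amine, a carboxylic acid or a longer chain such as butylsulfanyl would also stay within the scatter at this place remains open. So does the question of whether any single change on this ring can move the number beyond the scatter, since neither step shown here does so.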